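The compounds below may be only part of what the source reports. "The series", "measured", "known", "first", "only" and "open" are said of these compounds alone.

Measured so far in a functional assay on A549 cells (Homo sapiens) for inhibition, read by sulforhodamine B assay; a lower number here means a stronger inhibitor, a higher number a weaker inhibitor:

- Compound 1 `COC(=O)CC/C(C)=C/Cc1c(OC)c(C)c2c(c1OCC#CCN1CCN(C(c3ccc(F)cc3)c3ccc(F)cc3)CC1)C(=O)OC2`: 34100 nM
- Compound 2 `COC(=O)CC/C(C)=C/Cc1c(OC)c(C)c2c(c1OCC#CCN1CCN(c3ccc(O)cc3)CC1)C(=O)OC2`: > 50000 nM
- Compound 3 `CCCCNc1ccc(CC#CCOc2c(C/C=C(\C)CCC(=O)OC)c(OC)c(C)c3c2C(=O)OC3)cc1`: 6970 nM

Compound 2 is reported at > 50000 nM, which is a limit and not a number. That is the limit of > 50000 nM in this assay, at which 1 of the 3 values shown sits.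

The account now turns to compound 4 `COC(=O)CC/C(C)=C/Cc1c(OC)c(C)c2c(c1OCC#CCN1CCN(C(=O)C3COc4ccccc4O3)CC1)C(=O)OC2`, which has not yet been measured in this assay. It carries (2,3-dihydro-1,4-benzodioxin-2-yl)carbonyl in place of 4-hydroxyphenyl on an amine nitrogen in a ring.

For the measured compounds named here, no measured pair isolates this change, so the expectation rests on neighbouring values. Compound 1 also has a six-membered non-aromatic ring with 2 nitrogen, with a different group on it, and gives 34100 nM. On that value, a modest gain in inhibition is expected for the new compound, though it may also stay at the limit of the assay.

The expected size of the change is an at least 1.6-fold lower number from compound 2 to compound 4 (0.22 log units; that floor lies within the scatter).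

Compound 4 is estimated at 30000 nM, with an expected range from 12000 nM to 50000 nM.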

Compound 4, half-maximal inhibitory concentration: > 50000 nM
Compound 4 was reported as a limit; the forecaster's own chance of this, stated with the estimate: 40%; at least 1.6-fold (0.22 log units) between middle value and limit.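

Compound 4 gives > 50000 nM, which is a limit of the assay and not a number. Compound 2 is also reported at a limit, so no step can be read between these two compounds: the limit of > 50000 nM in this assay, at which 2 of the 4 values shown sit.

The compounds shown leave open whether (2,3-dihydro-1,4-benzodioxin-2-yl)carbonyl in place of 4-hydroxyphenyl changes inhibition at all.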